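The source may hold more compounds than are shown below. What is called first, only, known or untested is meant among the compounds shown, and "the series" means these compounds.

Measured compounds:
compound 1, `COc1cc(/C=C/C(=O)Nc2cc3c(Nc4ccc(F)c(Cl)c4)ncnc3cc2O[C@H]2CCOC2)cc(OC)c1O`: 30500 nM
compound 2, `COc1cc(/C=C/C(=O)Nc2cc3c(Nc4ccc(F)c(Cl)c4)ncnc3cc2O[C@H]2CCOC2)cc(OC)c1OC`: 28400 nM
compound 3, `COc1cc(/C=C/C(=O)Nc2cc3c(Nc4ccc(F)c(Cl)c4)ncnc3cc2OC)cc(OC)c1`: 38500 nM

In a functional assay on MCF7 cells (Homo sapiens) for cytotoxicity, read by MTT assay, with a stated time of 72 h (on this read-out higher numbers stand for weaker inhibition and lower numbers for stronger inhibition), compound 2 gives the lowest of the three numbers, but it stands within the scatter of both others: compound 1 sits a little higher, and compound 3, which carries a methoxy in place of the tetrahydrofuranyloxy group, sits higher still by a small margin. Among the compounds with values here, the only single-point step among them, a 1.1-fold lower number from compound 1 to compound 2 (0.03 log units; within the scatter), is also within the scatter, so all three measured compounds describe one flat level rather than a trend.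

Compound 4, `O=C(/C=C/c1cc(Br)c(O)c(Br)c1)Nc1cc2c(Nc3ccc(F)c(Cl)c3)ncnc2cc1O[C@H]1CCOC1`, is not yet measured. It differs from compound 2 in one place: 3,5-dibromo-4-hydroxyphenyl in place of 3,4,5-trimethoxyphenyl on a double-bonded chain carbon bound to a double-bonded chain carbon. Within the data shown here, no measured step touches this part of the molecule, since the one known step changes only a methyl on an oxygen within the trimethoxyphenyl group and produces no movement beyond the scatter. The expectation therefore rests on the flat level of compounds 1, 2 and 3 alone, and the step of a 1.1-fold lower number from compound 2 to compound 4 (0.06 log units; within the scatter) is expected to stay near zero. Compound 4 is estimated at 25000 nM, with a range of 8000 nM to 80000 nM.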

Compound 4, half-maximal inhibitory concentration: 30600 nM
Estimate against measurement, compound 4: 1.2-fold (0.09 log units) below, and the stated range covers the measured number.
By their numbers in this assay, from the lowest: compounds 2, 1, 4 and 3 (each within the scatter of the next).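

With 3,5-dibromo-4-hydroxyphenyl in place of 3,4,5-trimethoxyphenyl, the result is a 1.1-fold higher number from compound 2 to compound 4 (0.03 log units; within the scatter) in this assay and the same group in place of 4-hydroxy-3,5-dimethoxyphenyl gives a 1.0-fold higher number from compound 1 to compound 4 (0.00 log units; within the scatter) on this read-out. The earlier step changed only a methyl on an oxygen, whereas here two bromine atoms replace two methoxy groups on the ring, and the number still stays at the same flat level. Nothing measured here explains why the level holds through this larger change.

The compounds shown leave open whether any group on this ring can move the number beyond the scatter at all. An amine or a carboxylic acid in place of the ring's hydroxy group would test that, as would a longer chain between the ring and the amide carbonyl.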